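The compounds below may be only part of what the source reports. "The series", "measured", "known", "first", "only" and "open" are said of these compounds alone.

Working notes on the series. In a functional assay on the whole organism for agonist activity, with Rattus norvegicus as the target (a lower number here means that less compound is needed, a higher number that more compound is needed for the effect), compound 1 `Clc1cccc2c1CC2CCN1CCN(c2cccc3c2OCCO3)CC1` gives 40 mg/kg, and compound 2 `c1ccc2c(c1)CC2CCCN1CCN(c2cccc3c2OCCO3)CC1` gives 10 mg/kg; compound 2 therefore holds the lowest of the two numbers, its nearest neighbour being compound 1 at a step of a 4.0-fold lower number from compound 1 to compound 2 (0.60 log units; beyond the scatter). Compound 3 `C1=C(CCN2CCN(c3cccc4c3OCCO4)CC2)c2ccccc2C1` is the next candidate, reached by the change (a group of 9 heavy atoms (9 carbon; one five-membered non-aromatic ring of carbon only, one six-membered aromatic ring of carbon only) in place of a group of 9 heavy atoms (9 carbon; one four-membered non-aromatic ring of carbon only, one six-membered aromatic ring of carbon only), on a saturated chain carbon, two bonds along the chain from an amine nitrogen in a ring). For the measured compounds named here, no measured step swaps a four-membered non-aromatic ring for a five-membered one with a double bond outside aromatic rings; the only measured step, the one from compound 1 to compound 2, concerns a chlorine and is of modest size, so it gives no direction for this new change. Going by the values given here, with no comparable precedent, the expectation is a step of about no change at the digits printed from compound 2 to compound 3 (within the scatter), that is, nothing beyond the scatter, with a wide range to either side. Compound 3 is therefore estimated at 10 mg/kg in this assay, between 3 mg/kg and 40 mg/kg.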

Compound 3, minimum effective dose: > 2.5 mg/kg
Compound 3 was reported as a limit (the forecaster's own chance of this, stated with the estimate: 10%); the middle value lies beyond the limit too.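

In this assay compound 3 gives > 2.5 mg/kg, a limit and not a number, so the steps to compound 3 from compound 1 and from compound 2 cannot be read. As far as these compounds go, whether the five-membered ring group, in place of the four-membered one, lowers or raises the number stays open.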